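Shortening the alkynyl chain and cytotoxicity on HEL cells

The source may hold more compounds than are shown below. What is called first, only, known or untested is meant among the compounds shown, and "the series" means these compounds.

Measured compounds:
compound 1, `CCCCCCCC#Cc1cc2cn(COCCO)c(=O)nc2o1`: 200000 nM
compound 2, `CCCCCCCCC#Cc1cc2cn(COCCO)c(=O)nc2o1`: >= 20000 nM

In a functional assay on HEL cells (Homo sapiens), read by microscopy (on this read-out higher numbers stand for lower toxicity in this test and lower numbers for higher toxicity in this test), compound 1 gives 200000 nM, a high minimum cytotoxic concentration. For compound 2 the result is a limit of the assay, >= 20000 nM, so compound 2 stands at the limit of >= 20000 nM in this assay, at which 1 of the 2 values shown sits, rather than at a number. The step that the limit leaves unreadable from compound 1 to compound 2 therefore has no readable size. Compound 3, `CCCCCC#Cc1cc2cn(COCCO)c(=O)nc2o1`, is not yet measured in this assay. It differs from compound 2 by hydrogen in place of propyl on a saturated chain carbon, five bonds along the chain from a triple-bonded carbon. Among the measured compounds shown here, no measured step bears directly on this change, and the one step recorded cannot be read. Compound 1 shows low toxicity in this assay and compound 2 is only bounded. Compound 3 is therefore expected to stay in the low-toxicity region, with the step that the limit leaves unreadable from compound 2 to compound 3 expected to lie within the scatter. The estimate for compound 3 is 100000 nM, expected to fall between 20000 nM and 400000 nM.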

Compound 3, minimum cytotoxic concentration: >= 100000 nM
Compound 3 gave a limit, no number (the forecaster's own chance of this, stated with the estimate: 60%); the middle value lies on the limit itself.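

In this assay compound 3 gives only a limit of the assay, >= 100000 nM. Among the compounds shown here, no step among compound 1, compound 2 and compound 3 can therefore be read. The compounds shown leave open whether the length of the alkynyl chain changes the minimum cytotoxic concentration at all.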